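A few compounds are considered here, and "the series" means these few. Any claim that something is new, unique, unknown or untested is made for them only; others in the source may bear on it.

Compounds measured:
- compound 1, `CCc1cc(C(C)=O)c(O)cc1OCCCCCCCC(C)(C)C#N`: 29%
- compound 2, `CCc1cc(C(C)=O)c(O)cc1OCCCCCCSC`: 14%

Among the measured compounds shown here, in an assay on isolated protein for binding affinity to leukotriene B4 receptor 1 (Homo sapiens), tested at 1 uM (a lower number here means less inhibition, a higher number more inhibition at the concentration tested (going by the name of the read-out)), compound 2 gives the lower of the two numbers; the only step measured, a number 15 percentage points lower from compound 1 to compound 2 (beyond the scatter), lies beyond the scatter and leads down to it. The unmeasured compound 3, `CCc1cc(C(C)=O)c(O)cc1OCCCCCCC(=O)O`, differs from compound 2 by carboxy in place of methylsulfanyl on a saturated chain carbon, six bonds along the chain from an oxygen on an aromatic ring. For the measured compounds named here, no measured step exchanges a methylsulfanyl for a carboxy group, so the one step recorded bears on this change only in showing that what sits at the end of the chain can move this assay by a modest amount. Going by the values given here, with that as the sole guide, compound 3 is expected to lie above compound 2 by a step of about a number 16 percentage points higher from compound 2 to compound 3 (beyond the scatter), though the range is wide. The estimate for compound 3 is 30%, expected to fall between 10% and 55%.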

Compound 3, a percentage reported as inhibition, at one concentration (the size of the read-out at that concentration, not a potency): 38%
For compound 3 the middle estimate is 8 percentage points below the measured one; the measured number falls inside the stated range.
By their numbers in this assay, from the lowest: compound 2; then compounds 1 and 3 (each within the scatter of the next).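

In this assay, carboxy in place of methylsulfanyl at the end of the chain gives a number 24 percentage points higher from compound 2 to compound 3 (beyond the scatter), so a change at this position can raise the number as well as lower it. Carboxy in place of 2-cyano-2-methylpropyl gives a number 9 percentage points higher from compound 1 to compound 3 (within the scatter), so these two quite different end groups cannot be told apart here, and only compound 2 stands apart from both others. No independent measurement is available to explain the difference between carboxy and methylsulfanyl.

Going by these compounds, whether an amine, a primary amide or a methyl ester at the same place would group with compound 2 or with the other two remains open. On these data alone, it is also open how a shorter or longer chain ending in carboxy would read in this assay.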